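A few compounds are considered here, and "the series" means these few. Any claim that something is new, unique, unknown or untested is made for them only; others in the source may bear on it.

Working notes on the series.

Of the compounds shown here, two of the shared core have been measured in a functional assay on Jurkat cells for inhibition of nuclear factor NF-kappa-B complex (Homo sapiens); a lower number here means a stronger inhibitor, a higher number a weaker inhibitor. Compound 1 `CC1=CC(=O)N(Nc2nc(-c3cccs3)ncc2-c2cc(C)no2)C1=O` gives 300 nM. Going by the values given here, compound 2 `CC1=CC(=O)N(Nc2nc(-c3cccs3)ncc2C#N)C1=O` gives 5000 nM, the highest of the two numbers; the only measured step, a 17-fold higher number from compound 1 to compound 2 (1.22 log units; beyond the scatter), runs from compound 1 to compound 2.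

The next compound, compound 3 `CC1=CC(=O)N(Nc2nc(-c3cccs3)ncc2-c2nnn(C)n2)C1=O`, carries the change 2-methyl-2H-tetrazol-5-yl in place of cyano on an aromatic carbon on the six-membered aromatic ring with two nitrogens. Among the compounds with values here, the single step that bears on it is a 17-fold higher number from compound 1 to compound 2 (1.22 log units; beyond the scatter): replacing a five-membered aromatic ring on that carbon by cyano gave a large rise in the number. Compound 3 restores a five-membered aromatic ring at the same place, so a step in this assay back toward the number of compound 1 is expected, of size an 8.3-fold lower number from compound 2 to compound 3 (0.92 log units; beyond the scatter); whether the full distance is recovered cannot be told from one step. The estimate for compound 3 is 600 nM, with a range from 200 nM to 2000 nM.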

Compound 3, half-maximal inhibitory concentration: 200 nM
Beside the measured number, compound 3's estimate is 3.0-fold (0.48 log units) above it, and the stated range covers the measured number.
By their numbers in this assay, from the lowest: compounds 3 and 1 (each within the scatter of the next); then compound 2.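

In this assay the 2-methyl-2H-tetrazol-5-yl group brings the number back from the level seen with cyano at this position, with a 25-fold lower number from compound 2 to compound 3 (1.40 log units; beyond the scatter) and so the large loss of the earlier step is fully recovered. Against the 3-methyl-1,2-oxazol-5-yl group the change gives a 1.5-fold lower number from compound 1 to compound 3 (0.18 log units; within the scatter) and lies within the scatter, so these two five-membered aromatic rings, with different hetero atoms, cannot be told apart at this carbon. No evidence is available on what lies behind either step.

The compounds shown compare only cyano and two methyl-bearing five-membered aromatic rings on this carbon, so it remains open whether an unsubstituted ring, a phenyl ring, an amide or a carboxylic acid would hold the number there. On these data alone, the thiophen-2-yl group is constant throughout, and the effect of an amine or a phenyl ring in its place is also open.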